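The compounds below may be only part of what the source reports. "The series", "measured", "known", "first", "only" and "open" are said of these compounds alone.

Working notes on the series. For the measured compounds named here, in an assay on SHEP1 cells for agonist activity at Neuronal acetylcholine receptor; alpha4/beta2 (Homo sapiens), read by FLIPR and calcium flux (a lower number here means a smaller maximal response, a higher number a larger maximal response), compound 1 `C[C@@H]1C[C@H]1C(=O)N1CC2CNCC2C1` gives 100%, while compound 2 `CCC(=O)N1CC2CNCC2C1` gives 120%, the one measured step being a number 20 percentage points higher from compound 1 to compound 2 (beyond the scatter). Compound 3 `O=C(C1CC1)[C@H]1C[C@H]2CNC[C@H]2C1` gives 120% in this assay, level with compound 2 at the digits shown and, together with compound 2, at the top of the three numbers; its gap to compound 1 is beyond the scatter.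

Compound 4 `O=C(c1ccco1)[C@H]1C[C@H]2CNC[C@H]2C1` differs from compound 3 in one place: furan-2-yl in place of cyclopropyl on a carbonyl carbon. Going by the values given here, no measured step exchanges one ring for another at the carbonyl carbon, and the only measured step, a number 20 percentage points higher from compound 1 to compound 2 (beyond the scatter), concerns a chain against a ring instead; it bears on this change only loosely. A small step at most, in no settled direction, is therefore expected in this assay.

Compound 4 is estimated to give about 115% in this assay, between 90% and 140%. The expected step of a number 5 percentage points lower from compound 3 to compound 4 (within the scatter) is thus within the scatter.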

Compound 4, largest response reached (Emax), in percent of the reference or control that the assay uses: 94%
Compound 4: the middle estimate sits 21 percentage points above what was measured; low and high end bracket the measured number.
By their numbers in this assay, from the lowest: compounds 4 and 1 (each within the scatter of the next); then compounds 2 and 3 (each within the scatter of the next).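

In this assay the exchange of one ring for another on a carbonyl carbon is not neutral, with a number 26 percentage points lower from compound 3 to compound 4 (beyond the scatter) on going from cyclopropyl to furan-2-yl. The earlier step set a chain against a ring on a different core, whereas this one shows that the maximal response on the shared core of compound 3 also depends on which ring stands at this place. Nothing available accounts for the size or direction of this step.

Going by these compounds, whether thiophen-2-yl, phenyl or a longer chain on this carbonyl carbon would sit nearer compound 3 or compound 4 stays open. Also open, on these data alone, is whether the step goes with the ring oxygen or with the larger ring.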